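Amide nitrogen substituent change from compound 2 to compound 4

A few compounds are considered here, and "the series" means these few. Any claim that something is new, unique, unknown or untested is made for them only; others in the source may bear on it.

Compound 2 `COc1ccc(NC(=O)c2c(NO)cc(-c3ccccc3)oc2=O)cc1` stands at the ceiling of the numbers shown. In an ADME assay on Huh-7 cells (Homo sapiens) for cytotoxicity, read by a luciferase reporter and WST assay, with a stated time of 3 days (on this read-out higher numbers stand for lower toxicity in this test and lower numbers for higher toxicity in this test), compound 2 gives > 20000 nM, which is a limit of the test and not a number. Compound 3 `COC(=O)c1ccc(NC(=O)c2c(NO)cc(-c3ccccc3)oc2=O)cc1` likewise returns only a limit in this assay, > 20000 nM. Within the data shown here, compound 1 `O=C(Nc1ccccc1)c1c(NO)cc(-c2ccc(Cl)cc2)oc1=O` is the one member of the set with a measured value in this assay, where compound 1 gives 11000 nM. Among the measured compounds shown here, the only one-place step among the measured compounds, a step that the two limits leave unreadable from compound 2 to compound 3, cannot be sized since both of its ends sit at the limit of > 20000 nM in this assay, at which 2 of the 3 values shown sit.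

Compound 4 `COC(=O)CNC(=O)c1c(NO)cc(-c2ccccc2)oc1=O` differs from compound 2 at the amide-type nitrogen: (methoxycarbonyl)methyl in place of 4-methoxyphenyl on an amide-type nitrogen. For the measured compounds named here, no measured step touches this position in a readable way; the one step at the amide nitrogen is the unreadable one from compound 2 to compound 3. Going by the values given here, the two compounds varied at the amide nitrogen, compound 2 and compound 3, both sit at the limit, so the working expectation is that compound 4 also falls at or near that limit, with no step in this assay beyond the scatter. The step expected from compound 2 to compound 4 is therefore flat, a number no higher from compound 2 to compound 4 (the limit leaves the size open). Compound 4 is estimated at 20000 nM, with a range from 9000 nM to 45000 nM, most likely reported again only as a limit.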

Compound 4, half-maximal cytotoxic concentration: > 20000 nM
Compound 4 was reported as a limit; the forecaster's own chance of this, stated with the estimate: 65%; the middle value lies on the limit itself.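

In this assay compound 4 gives > 20000 nM, a limit and not a number. Among these compounds, compound 2 also stands at a limit, so no step between compound 2 and compound 4 can be read. The compounds shown leave open whether the group on the amide-type nitrogen shifts the half-maximal cytotoxic concentration at all: the limit of > 20000 nM in this assay, at which 3 of the 4 values shown sit.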